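Swapping a methylpyridine for a methylpyrazole on the amide

The compounds below may be only part of what the source reports. "The series", "measured", "known", "first", "only" and "open" are said of these compounds alone.

Of the compounds shown here, two have been measured in a functional assay on CHO cells for inhibition of Orexin receptor type 2 (Homo sapiens), read by FLIPR and calcium flux; a lower number here means a stronger inhibitor, a higher number a weaker inhibitor. Compound 1 `CCN(CC)C(=O)CN(c1cccc(N(C)C)c1C#N)S(=O)(=O)c1ccc(OC)c(OC)c1` gives 110 nM. Compound 2 `CCN(C(=O)CN(c1cc(N(C)C)ccc1Cl)S(=O)(=O)c1ccc(OC)c(OC)c1)c1cccc(C)n1` gives 5 nM, the lower of the two numbers and therefore the stronger inhibitor, with a gap to compound 1 that lies beyond the usual scatter of this assay. Compound 2 is thus the better starting point for the next change.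

Compound 3 `CCN(C(=O)CN(c1cc(N(C)C)ccc1Cl)S(=O)(=O)c1ccc(OC)c(OC)c1)c1ccn(C)n1` keeps everything in compound 2 except one group: 1-methyl-1H-pyrazol-3-yl in place of 6-methylpyridin-2-yl on an amide-type nitrogen. The amide nitrogen still carries its ethyl group; only the aromatic ring attached to it is exchanged, a six-membered ring with one nitrogen giving way to a five-membered ring with two nitrogens.

Among the measured compounds shown here, no measured pair in this set shows this exact swap, so there is no measured step to lean on. Compound 3 is expected to remain an active inhibitor while losing some ground, the expected step being a 3.0-fold higher number from compound 2 to compound 3 (0.48 log units; beyond the scatter), a moderate move toward a higher number rather than a collapse. On that basis compound 3 is estimated at 15 nM in this assay, with a plausible range from 4 nM to 60 nM.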

Compound 3, half-maximal inhibitory concentration: 7 nM
Beside the measured number, compound 3's estimate is 2.1-fold (0.33 log units) above it, and the stated range covers the measured number.
By their numbers in this assay, from the lowest: compounds 2 and 3 (each within the scatter of the next); then compound 1.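

In this assay, putting 1-methyl-1H-pyrazol-3-yl in place of 6-methylpyridin-2-yl on the amide-type nitrogen gives a 1.4-fold higher number from compound 2 to compound 3 (0.15 log units; within the scatter) and so leaves the two compounds indistinguishable in this test. Among the compounds shown here, this pair therefore shows that, at this one position, a six-membered aromatic ring with one hetero atom and a five-membered aromatic ring with two hetero atoms can be exchanged without a difference larger than repeat measurements would produce, something the earlier compounds could not show since they differ in more than one place. Nothing available explains why the two rings read alike.

On these data alone, what remains open is how much of the ring this position needs: whether the methyl group on the ring matters could be tested with an unsubstituted pyrazole, and whether an aromatic ring is needed at all could be tested with a saturated group such as cyclopropyl or cyclohexyl. The ethyl group on the same nitrogen is also untested by these compounds, so a methyl group or a longer chain such as propyl there could read differently.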